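Chlorine position in the phenoxy group of the series

The source may report more compounds than this note shows. Statements on the series, on what has been measured and on what is new or still open speak of the compounds shown alone.

In a functional assay for inhibition of sodium/hydrogen exchanger (Oryctolagus cuniculus) (a lower number here means a stronger inhibitor, a higher number a weaker inhibitor), compound 1 `Cc1cc(-c2ccco2)c(S(C)(=O)=O)cc1C(=O)N=C(N)N` gives 16 nM, and compound 2 `Cc1cc(Oc2ccccc2Cl)c(S(C)(=O)=O)cc1C(=O)N=C(N)N` gives 14 nM. For the measured compounds named here, the only measured step, a 1.1-fold lower number from compound 1 to compound 2 (0.06 log units; within the scatter), lies within the scatter. Compound 2 thus holds the lowest of the two numbers, with compound 1 nearest and within the scatter, so no order between the two can be read from this pair. Compound 3 `Cc1cc(Oc2cccc(Cl)c2)c(S(C)(=O)=O)cc1C(=O)N=C(N)N` differs from compound 2 by 3-chlorophenyl in place of 2-chlorophenyl on an oxygen on an aromatic ring. Going by the values given here, no measured step moves a chlorine within a phenoxy ring; the single step available exchanges furan-2-yl for 2-chlorophenoxy as a whole and stayed within the scatter, so it bears only loosely on the present change. On that basis the step of no change at the digits printed from compound 2 to compound 3 (within the scatter) is expected to stay within the scatter, with no direction to assign. Compound 3 is estimated at 14 nM in this assay, with a range from 5 nM to 45 nM.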

Compound 3, half-maximal inhibitory concentration: 21 nM
Compound 3: middle estimate off by 1.5-fold (0.18 log units), on the low side, and the stated range covers the measured number.
By their numbers in this assay, from the lowest: compounds 2, 1 and 3 (each within the scatter of the next).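

In this assay, for the compounds shown here, the exchange of 2-chlorophenyl for 3-chlorophenyl on the oxygen gives a 1.5-fold higher number from compound 2 to compound 3 (0.18 log units; within the scatter) and is the first step that alters only where the chlorine sits, without separating the two chlorophenoxy groups. The exchange of furan-2-yl for 3-chlorophenoxy gives a 1.3-fold higher number from compound 1 to compound 3 (0.12 log units; within the scatter) and so, like the earlier step to 2-chlorophenoxy, does not separate the chlorophenoxy group from furan-2-yl on the shared core. No measurement is at hand that would account for these numbers.

As far as these compounds go, whether a phenoxy group carrying no chlorine, a fluorine in place of the chlorine, or an amine such as piperidine at this place would give a number beyond the scatter of these three stays open. Also open, from the compounds shown here alone, is what a longer alkyl chain with no aromatic ring would give here.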